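Chain lengthening in a triazole series: cytotoxicity working notes

The source may report more compounds than this note shows. Statements on the series, on what has been measured and on what is new or still open speak of the compounds shown alone.

Measured compounds:
compound 1, `CC[C@H](CCn1cncn1)c1ccccc1`: in an ADME assay on RD cells (Homo sapiens) for cytotoxicity, read by MTT assay, with a stated time of 3 days (on this read-out lower numbers stand for higher toxicity in this test and higher numbers for lower toxicity in this test), compound 1 gives 99.8 ug/mL.
compound 2, `CCC[C@H](CCn1cncn1)c1ccccc1`: compound 2 gives 63.1 ug/mL.
compound 3, `CCC[C@H](CCn1cncn1)c1ccc(F)cc1`: compound 3 gives 38.4 ug/mL.

Compound 2 sits second highest of the three numbers, with compound 1 nearest and compound 3 furthest; both of its steps, a 1.6-fold lower number from compound 1 to compound 2 (0.20 log units; within the scatter) and a 1.6-fold lower number from compound 2 to compound 3 (0.22 log units; within the scatter), lie within the scatter. Compound 4, `CCCC[C@H](CCn1cncn1)c1ccccc1`, differs from compound 2 by methyl in place of hydrogen on a saturated chain carbon, four bonds along the chain from an aromatic carbon. Among the compounds with values here, the one step that bears on this is the earlier chain extension from compound 1 to compound 2, a 1.6-fold lower number from compound 1 to compound 2 (0.20 log units; within the scatter), which stayed within the scatter. No step beyond the scatter is therefore expected in this assay, at most a slight drift downward: compound 4 is estimated at 50 ug/mL, range 25 ug/mL to 100 ug/mL, meaning an expected step of a 1.3-fold lower number from compound 2 to compound 4 (0.10 log units; within the scatter).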

Compound 4, half-maximal cytotoxic concentration: 48.3 ug/mL
The estimate for compound 4 lay 1.0-fold (0.02 log units) above the measured number; the range from low to high includes it.
By their numbers in this assay, from the lowest: compounds 3, 4, 2 and 1 (each within the scatter of the next, the first and the last beyond it).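

In this assay, methyl in place of hydrogen at this chain carbon gives a 1.3-fold lower number from compound 2 to compound 4 (0.12 log units; within the scatter), so this extension alone stays within the scatter, as the previous one did. Taken together, the two extensions give the first step in the chain series beyond the scatter, a modest one: a 2.1-fold lower number from compound 1 to compound 4 (0.32 log units; beyond the scatter). Nothing available gives a reason for this step.

Going by these compounds, whether a pentyl or longer chain would extend this downward run remains open. So does the reading for a hydroxyl or an amine on this same chain carbon.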